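The source may report more compounds than this note shows. Statements on the series, on what has been measured and on what is new or still open speak of the compounds shown alone.

Measured so far in an ADME assay on MT4 cells (Homo sapiens) for cytotoxicity, read by spectrophotometry, with a stated time of 5 days; a lower number here means that less compound is tolerated, a higher number that more compound is tolerated:

- Compound 1 `Cc1ccc2c(c1)/C(=N/NC(=S)NO)C(=O)N2CN(C)C`: 651000 nM
- Compound 2 `CCN(CC)CN1C(=O)/C(=N\NC(=S)NOC)c2cc(C)ccc21`: 573000 nM
- Compound 3 `CCN(CC)CN1C(=O)/C(=N\NC(=S)NO)c2cc(F)ccc21`: 521000 nM

Compound 3 gives 521000 nM, and the values of the other two compounds both lie within the usual scatter of that number. On these data, compound 3 cannot be told apart from compound 1 or compound 2, and all three are tolerated up to similar concentrations.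

The next compound, compound 4 `CCN(CC)CN1C(=O)/C(=N\NC(=S)NO)c2cc(C)ccc21`, has methyl in place of fluoro on an aromatic carbon. The rest of its structure matches compound 3. Within the data shown here, no two measured compounds differ in only one place, so the effect of this exchange has not been measured directly.

The closest evidence comes from two compounds that carry methyl on the ring and differ from compound 4 elsewhere. Compound 1 gives 651000 nM, and compound 2 gives 573000 nM. Neither value stands apart from that of compound 3, so no change beyond the scatter is expected in this assay.

The expected change is small, an estimated 1.1-fold higher number from compound 3 to compound 4 (0.04 log units; within the scatter), with no firm direction. For compound 4, the estimated value is 570000 nM, with an expected range from 320000 nM to 950000 nM.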

Compound 4, half-maximal cytotoxic concentration: 534000 nM
Compound 4: the middle estimate sits 1.1-fold (0.03 log units) above what was measured; low and high end bracket the measured number.
By their numbers in this assay, from the lowest: compounds 3, 4, 2 and 1 (each within the scatter of the next).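

In this assay the exchange of fluoro for methyl on this aromatic carbon can now be read directly as a 1.0-fold higher number from compound 3 to compound 4 (0.01 log units; within the scatter) and so the two groups cannot be told apart here, at least on the shared core of compound 3 and compound 4. The same result also opens two further one-place comparisons elsewhere in the structure, with hydrogen in place of methyl on an oxygen giving a 1.1-fold lower number from compound 2 to compound 4 (0.03 log units; within the scatter) and diethylamino in place of dimethylamino on the saturated chain carbon giving a 1.2-fold lower number from compound 1 to compound 4 (0.09 log units; within the scatter) and neither exchange separating its pair of compounds in this assay. No supporting measurement bears on this result.

Going by these compounds, whether a nitrile, a methoxy group or a carboxylic acid on this aromatic carbon would also stay within the scatter of compound 4 remains open. On these data alone, it is equally open whether a longer chain on the oxygen, or a piperidine ring in place of diethylamino, would leave the number just as undisturbed.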